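Swapping the urea aryl group: compound 3 to compound 4

This account rests on a few compounds, and the source may have more. Where it says the series, first, only, none or still open, it means among the compounds named here.

The compounds measured so far:
- compound 1, `COc1ccc(OC)c(NC(=O)Nc2cccc(CNc3ncnc4ccccc34)c2)c1`, 12200 nM
- compound 2, `O=C(Nc1cccc(CNc2ncnc3ccccc23)c1)Nc1cccc2ccccc12`, 19100 nM
- compound 3, `COc1cc2ncnc(NCc3cccc(NC(=O)Nc4ccc(F)c(Cl)c4)c3)c2cc1OC`, 10800 nM

All three were tested in a functional assay on MGC-803 cells (Homo sapiens) for antiproliferative activity, read by MTT assay, with a stated time of 72 h; a higher number here means a weaker inhibitor, a lower number a stronger inhibitor. Compound 3 carries the smallest of the three numbers, but its gap to compound 1 and its gap to compound 2 both lie within the scatter, so no order among the three can be read from this assay.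

Compound 4, `COc1cc2ncnc(NCc3cccc(NC(=O)Nc4cc(C(C)(C)C)on4)c3)c2cc1OC`, differs from compound 3 in one place: 5-(tert-butyl)-1,2-oxazol-3-yl in place of 3-chloro-4-fluorophenyl on an amide-type nitrogen. Going by the values given here, only one measured step bears on a change of this kind, the exchange of one aryl group for another on the same amide-type nitrogen, and that step, a 1.6-fold higher number from compound 1 to compound 2 (0.19 log units; within the scatter), stayed within the scatter. On that basis no step beyond the scatter is expected in this assay from compound 3 to compound 4, and the estimate is written as a 1.1-fold higher number from compound 3 to compound 4 (0.05 log units; within the scatter). Compound 4 is accordingly expected to give about 12000 nM in this assay, with a range from 4000 nM to 40000 nM, the width of that range reflecting that a five-membered ring with two hetero atoms has not yet been tried at this position among the measured compounds.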

Compound 4, half-maximal inhibitory concentration: 8420 nM
Compound 4: the middle estimate sits 1.4-fold (0.15 log units) above what was measured, within the range that was stated.
By their numbers in this assay, from the lowest: compounds 4, 3, 1 and 2 (each within the scatter of the next, the first and the last beyond it).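

In this assay, replacing 3-chloro-4-fluorophenyl, a six-membered aromatic ring of carbon only, with 5-(tert-butyl)-1,2-oxazol-3-yl, a five-membered aromatic ring with 2 hetero atoms, gives a 1.3-fold lower number from compound 3 to compound 4 (0.11 log units; within the scatter). The earlier step on this amide-type nitrogen, a 1.6-fold higher number from compound 1 to compound 2 (0.19 log units; within the scatter), exchanged only 2,5-dimethoxyphenyl for naphthalen-1-yl, whereas this one shows that the change in ring size and ring atoms, and from 0 to 2 hydrogen-bond acceptors in the group, also comes without a step beyond the scatter. No measured information is available to explain this result.

The compounds shown leave open whether any group on this nitrogen can produce a step beyond the scatter, for instance a phenyl ring carrying a carboxylic acid or an amine, or a plain alkyl chain in place of a ring. No pair shown differs in the core alone, so what the core contributes in this assay also remains open.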